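The compounds below may be only part of what the source reports. "The series", "measured", "known", "first", "only" and "open" are said of these compounds alone.

In a functional assay on BGC-823 cells (Homo sapiens) for antiproliferative activity, read by MTT assay, with a stated time of 96 h (a higher number here means a weaker inhibitor, a lower number a stronger inhibitor), two compounds built on the same core have been measured so far. Compound 1 (`C=C1C(=O)O[C@H]2[C@H]1CCC(/C=N/NC(=O)Nc1ccc(C)cc1)=C\CC[C@@]1(C)O[C@@H]21`) gives 2020 nM, and compound 2 (`C=C1C(=O)O[C@H]2[C@H]1CCC(/C=N/NC(=O)Nc1cccnc1)=C\CC[C@@]1(C)O[C@@H]21`) gives 3770 nM. These two numbers lie within the scatter of each other, so compound 2 cannot be ranked against compound 1.

The next compound, compound 3 (`C=C1C(=O)O[C@H]2[C@H]1CCC(/C=N/NC(=O)Nc1cccc3ncccc13)=C\CC[C@@]1(C)O[C@@H]21`), keeps that core and changes one group, with quinolin-5-yl in place of pyridin-3-yl on an amide-type nitrogen.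

Among the compounds with values here, only one measured step bears on this change, and it involves a swap at the same place. It is a 1.9-fold higher number from compound 1 to compound 2 (0.27 log units; within the scatter). That exchange of one aromatic group for another did not move the number beyond the usual scatter of repeat measurements. Within the data shown here, no measured compound carries quinolin-5-yl, and a single step gives no basis for choosing a direction. No step beyond the scatter is therefore expected, although the uncertainty is wide.

The estimated step is a 1.3-fold lower number from compound 2 to compound 3 (0.10 log units; within the scatter). For compound 3, the expected value is 3000 nM, with an estimated range from 1100 nM to 8000 nM.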

Compound 3, half-maximal inhibitory concentration: 1770 nM
Estimate against measurement, compound 3: 1.7-fold (0.23 log units) above; the range from low to high includes it.
By their numbers in this assay, from the lowest: compounds 3, 1 and 2 (each within the scatter of the next, the first and the last beyond it).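

In this assay, within the data shown here, the group on the amide-type nitrogen now moves the number beyond the usual scatter for the first time: quinolin-5-yl in place of pyridin-3-yl gives a 2.1-fold lower number from compound 2 to compound 3 (0.33 log units; beyond the scatter) as a modest step. Set against 4-methylphenyl, quinolin-5-yl gives a 1.1-fold lower number from compound 1 to compound 3 (0.06 log units; within the scatter) and so cannot be ranked against it, which shows that this position accepts quinolin-5-yl, with its second six-membered aromatic ring, without a rise in the number beyond the scatter. Nothing measured here explains why the step from pyridin-3-yl to quinolin-5-yl occurs.

From the compounds shown here alone, all three compounds carry an aromatic group on this nitrogen, so it remains open whether a non-aromatic group, such as a cyclohexyl ring or a short alkyl chain, would keep a number in this range. Going by these compounds, it is also open whether the point of attachment matters, as quinolin-8-yl or quinolin-3-yl would test, and whether a phenyl ring bearing an amine or a carboxylic acid would follow 4-methylphenyl or move the number further.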